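Swapping the benzyl group on the amide nitrogen

This account rests on a few compounds, and the source may have more. Where it says the series, first, only, none or still open, it means among the compounds named here.

In a functional assay on A2780 cells (Homo sapiens) for antiproliferative activity, read by resazurin assay, with a stated time of 72 h (on this read-out lower numbers stand for stronger inhibition and higher numbers for weaker inhibition), compound 1 `CCCN(C)C(=O)c1cc2c(Cc3ccccc3)n[nH]c2cc1O` returns only a limit of the assay, > 10000 nM. Among the measured compounds shown here, compound 2 `Cc1ccccc1CN(C)C(=O)c1cc2c(Cc3ccccc3)n[nH]c2cc1O` gives 4400 nM, the only true number so far. Compound 3 `CN(Cc1ccc(F)cc1)C(=O)c1cc2c(Cc3ccccc3)n[nH]c2cc1O` differs from it in one place: 4-fluorophenyl in place of 2-methylphenyl on a saturated chain carbon bound to an amide-type nitrogen. That is, 4-fluorophenyl in place of 2-methylphenyl on a saturated chain carbon bound to an amide-type nitrogen. For the measured compounds named here, the one measured step at this place, an at least 2.2-fold lower number from compound 1 to compound 2 (0.35 log units; beyond the scatter), replaced ethyl rather than one aromatic group with another, so it gives only weak guidance. No change beyond the scatter is therefore expected, and the estimated step is a 1.1-fold higher number from compound 2 to compound 3 (0.06 log units; within the scatter). Compound 3 is expected at 5000 nM, with an estimated range of 2000 nM to 12000 nM.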

Compound 3, half-maximal inhibitory concentration: 4100 nM
Compound 3: the middle estimate sits 1.2-fold (0.09 log units) above what was measured, and the stated range covers the measured number.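

Replacing 2-methylphenyl with 4-fluorophenyl gives a 1.1-fold lower number from compound 2 to compound 3 (0.03 log units; within the scatter) in this assay, so these two aromatic groups cannot be told apart at this position. A second aromatic group in place of ethyl also lowers the number, with an at least 2.4-fold lower number from compound 1 to compound 3 (0.38 log units; beyond the scatter). The full size of that step cannot be read because compound 1 stands at a limit of the assay: the limit of > 10000 nM in this assay, at which 1 of the 3 values shown sits.

The compounds shown leave open how a pyridine ring, a cyclohexyl group or a carboxylic acid would behave on this saturated chain carbon.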